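A few compounds are considered here, and "the series" means these few. Any claim that something is new, unique, unknown or untested is made for them only; others in the source may bear on it.

Going by the values given here, compound 3 `CCCCCc1ccc(-c2cn(-c3cccc(C(=O)/C=C/c4ccc(O)c(OC)c4)c3)nn2)cc1` gives the lowest number of the three measured so far in a functional assay on RAW264.7 cells (Mus musculus) for inhibition, with a stated time of 4 days (a higher number here means a weaker inhibitor, a lower number a stronger inhibitor), at 5780 nM. Compound 1 `COc1cc(/C=C/C(=O)c2cccc(-n3cc(-c4ccccc4)nn3)c2)ccc1O` gives 16800 nM and compound 2 `COc1cc(/C=C/C(=O)c2cccc(-n3cc(-c4ccc(C)cc4)nn3)c2)ccc1O` gives 15400 nM; the steps of a 2.9-fold lower number from compound 1 to compound 3 (0.46 log units; beyond the scatter) and a 2.7-fold lower number from compound 2 to compound 3 (0.43 log units; beyond the scatter) both set compound 3 apart, whereas the step of a 1.1-fold lower number from compound 1 to compound 2 (0.04 log units; within the scatter) does not. Compound 4 `COc1cc(/C=C/C(=O)c2cccc(-n3cc(-c4cccc(Cl)c4)nn3)c2)ccc1O` differs from compound 3 in one place: 3-chlorophenyl in place of 4-pentylphenyl on an aromatic carbon. The step of a 2.9-fold lower number from compound 1 to compound 3 (0.46 log units; beyond the scatter) bears most on this change: the pentyl group that entered there now leaves. The step of a 1.1-fold lower number from compound 1 to compound 2 (0.04 log units; within the scatter) shows a small group in that position adding little. For compound 4 a step back toward the weaker end is therefore expected, a 2.4-fold higher number from compound 3 to compound 4 (0.38 log units; beyond the scatter). In this assay compound 4 is estimated at 14000 nM, with a range from 6000 nM to 30000 nM.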

Compound 4, half-maximal inhibitory concentration: 14300 nM
The estimate for compound 4 lay 1.0-fold (0.01 log units) below the measured number, within the range that was stated.
By their numbers in this assay, from the lowest: compound 3; then compounds 4, 2 and 1 (each within the scatter of the next).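

Putting 3-chlorophenyl in place of 4-pentylphenyl gives a 2.5-fold higher number from compound 3 to compound 4 (0.39 log units; beyond the scatter), so a chlorine on this phenyl ring does not match what the pentyl chain achieved. In this assay, chloro in place of hydrogen gives a 1.2-fold lower number from compound 1 to compound 4 (0.07 log units; within the scatter) and 3-chlorophenyl in place of 4-methylphenyl gives a 1.1-fold lower number from compound 2 to compound 4 (0.03 log units; within the scatter), so among these four compounds only compound 3, with its pentyl chain, stands apart. Nothing here explains why the pentyl chain stands apart. Open, as far as these compounds go, is whether a butyl or octyl chain on this phenyl ring would also stand apart, and how an amine or a carboxylic acid there would compare.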